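Formyl to Cyano on a Fused Heteroaromatic Core

The compounds below may be only part of what the source reports. "The series", "measured", "known", "first", "only" and "open" are said of these compounds alone.

Compound 1 `Cc1ccc2c(Cc3nn4c(C=O)c(-c5ccc(Cl)cc5)nc4s3)coc2c1` was tested in a functional assay on the whole organism (strain Wistar albino) for inhibition, with Rattus norvegicus as the target, read by paw edema, with a stated time of 0.5 h, at a dose of 100 mg/kg by the oral route (a higher number here means more inhibition at the dose given (going by the name of the read-out), a lower number less inhibition), where compound 1 gives 3.6%. Its one comparator, compound 2 `Cc1ccc2c(Cc3nn4c(C=O)c(-c5ccc(Br)cc5)nc4s3)coc2c1`, gives 1.15% in this assay, and the move a number 2.5 percentage points lower from compound 1 to compound 2 (within the scatter) is a change of halogen only. On these two numbers compound 1 stands highest, but the gap to compound 2 lies within the scatter, so no order between them can be claimed.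

Compound 3 `Cc1ccc2c(Cc3nn4c(C#N)c(-c5ccc(Cl)cc5)nc4s3)coc2c1` has not yet been measured. It differs from compound 1 by cyano in place of formyl on an aromatic carbon, on an aromatic carbon of a five-membered aromatic ring with two nitrogens within the fused system, next to the ring atom that bears the 4-chlorophenyl group. Going by the values given here, no measured step touches this position; the only measured step concerns the halogen on the pendant ring and was itself within the scatter. Both measured values sit near the floor of the read-out. Compound 3 is therefore expected to show a step of a number 0.6 percentage points lower from compound 1 to compound 3 (within the scatter), with no change beyond the scatter, and its inhibition in this assay is estimated at 3%, between -5% and 12%.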

Compound 3, a percentage reported as inhibition, in the whole organism at one dose (the size of the read-out at that dose, not a potency): 4.77%
Beside the measured number, compound 3's estimate is 1.8 percentage points below it; the range from low to high includes it.
By their numbers in this assay, from the lowest: compounds 2, 1 and 3 (each within the scatter of the next).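

Going by these compounds alone, the change from formyl to cyano gives the first measured step at this position, on an aromatic carbon of a five-membered aromatic ring with two nitrogens, and in this assay it is a number 1.2 percentage points higher from compound 1 to compound 3 (within the scatter). The position therefore accepts cyano in place of formyl with no difference that can be told from the scatter, although both groups give inhibition near the floor of the read-out, so the comparison has little room to show a loss. Nothing measured here offers an explanation for this result.

The compounds shown leave open whether any group at this carbon can lift the inhibition clear of that floor, for instance an amine, a carboxylic acid or a longer chain. They also leave open whether bromo in place of chloro would read the same with cyano present.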